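The source may hold more compounds than are shown below. What is called first, only, known or untested is meant among the compounds shown, and "the series" means these compounds.

Compound 1 `Cc1nc(-c2nc3ccccc3[nH]2)c(N2CCN(C(=O)Cn3cnc4cccnc43)[C@H](C)C2)s1` gave 1060 nM in an assay on blood for inhibition of C-X-C chemokine receptor type 3 (Homo sapiens), with a stated time of 30 min; a higher number here means a weaker inhibitor, a lower number a stronger inhibitor.
Compound 2 `C[C@@H]1CN(c2sc(C3CC3)nc2-c2nc3ccccc3[nH]2)CCN1C(=O)Cn1cnc2cccnc21` gave 994 nM in this assay.
Compound 3 `Cc1nc(C)n(CC(=O)N2CCN(c3sc(C(F)(F)F)nc3-c3cnc(OC(C)C)nc3)C[C@H]2C)n1` gave 216 nM in this assay.

For the measured compounds named here, of these three numbers, compound 3 has the lowest, and its gap to compound 2 and to compound 1 is beyond the scatter in both cases, so compound 3 is the strongest inhibitor of the three measured so far.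

Compound 4 `CCOc1ccc(-c2nc(C(F)(F)F)sc2N2CCN(C(=O)Cn3nc(C)nc3C)[C@H](C)C2)cn1` differs from compound 3 in a single place: 6-ethoxypyridin-3-yl in place of 2-isopropoxypyrimidin-5-yl on an aromatic carbon. Going by the values given here, the only measured step, a 1.1-fold lower number from compound 1 to compound 2 (0.03 log units; within the scatter), concerns a different ring position and a different kind of exchange, and it stayed within the scatter, so no measured step bears directly on the change from compound 3 to compound 4. With nothing in the data to point either way, the expectation is a step of about a 1.4-fold higher number from compound 3 to compound 4 (0.14 log units; within the scatter), that is, no change beyond the scatter. Compound 4 is therefore expected to give roughly 300 nM in this assay, with a range from 100 nM to 900 nM.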

Compound 4, half-maximal inhibitory concentration: 887 nM
Compound 4: the middle estimate sits 3.0-fold (0.47 log units) below what was measured; the range from low to high includes it.
By their numbers in this assay, from the lowest: compound 3; then compounds 4, 2 and 1 (each within the scatter of the next).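

At the aromatic carbon next to the ring nitrogen, replacing 2-isopropoxypyrimidin-5-yl with 6-ethoxypyridin-3-yl gives a 4.1-fold higher number from compound 3 to compound 4 (0.61 log units; beyond the scatter) in this assay, so the number read in this assay depends on which of these two groups sits at this position. The exchange alters two things at once, since the six-membered aromatic ring goes from 2 hetero atoms to 1 and the isopropoxy chain becomes an ethoxy chain, and this single pair cannot show which of the two carries the step. No measurement available here offers a reason for the step.

Still open, going by these compounds, is whether an ethoxy chain on the pyrimidine ring, or an isopropoxy chain on the pyridine ring, would separate these two parts of the exchange. Also open, on these data alone, is how this position would respond to an amine or a longer chain in place of these ether chains.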